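Substance-P receptor series: chloro to bromo on the fused ring

A few compounds are considered here, and "the series" means these few. Any claim that something is new, unique, unknown or untested is made for them only; others in the source may bear on it.

Measured so far in an assay on CHO cells for displacement of a labelled ligand from Substance-P receptor (Homo sapiens); on this read-out higher numbers stand for weaker inhibition and lower numbers for stronger inhibition:
compound 1 `COc1ccccc1N1CCN(C(=O)CCc2c(-c3ccccc3)[nH]c3ccc(Cl)cc23)CC1` gives 5.6 nM
compound 2 `COc1ccccc1N1CCN(C(=O)CCc2c(-c3ccc(Cl)cc3)[nH]c3c(Cl)cc(Cl)cc23)CC1` gives 14 nM
compound 3 `Cn1c(-c2ccc(Cl)cc2)c(CCC(=O)N2CCC(O)(Cc3ccccc3)CC2)c2cc(Cl)ccc21` gives 0.16 nM

Compound 3 stands lowest of the three numbers in this assay. Its gap to compound 1 is the nearest and lies beyond the scatter; its gap to compound 2 is the widest and also lies beyond the scatter. Compound 1 and compound 2 differ from compound 3 in several places at once, so no single exchange among the measured compounds can be read on its own.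

Compound 4 `Cn1c(-c2ccc(Cl)cc2)c(CCC(=O)N2CCC(O)(Cc3ccccc3)CC2)c2cc(Br)ccc21` differs from compound 3 in one place only: bromo in place of chloro on an aromatic carbon. For the measured compounds named here, none of the measured pairs shows this exchange, so no step between measured compounds is available to set its size. Going by the values given here, with nothing among the measured compounds pointing in either direction, the expectation is a step of no more than the scatter, in no fixed direction. The expected step is a 1.1-fold higher number from compound 3 to compound 4 (0.05 log units; within the scatter), which is expected to stay within the scatter. Resting on compound 3 with its value of 0.16 nM, compound 4 is expected to give 0.18 nM in this assay, with a range from 0.07 nM to 0.5 nM.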

Compound 4, half-maximal inhibitory concentration: 0.22 nM
Estimate against measurement, compound 4: 1.2-fold (0.09 log units) below; the range from low to high includes it.
By their numbers in this assay, from the lowest: compounds 3 and 4 (each within the scatter of the next); then compound 1; then compound 2.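

In this assay, for the compounds shown here, a 1.4-fold higher number from compound 3 to compound 4 (0.14 log units; within the scatter) is the first step that can be read on its own, since all earlier comparisons involved several places at once. At this aromatic carbon of the fused system, bromo and chloro cannot be told apart on this read-out, so the exchange of one halogen for the other, with one heavy atom leaving and one entering and no hydrogen-bond donor, acceptor or net charge involved, leaves the two compounds equivalent within the scatter. No measurement at hand bears on why the two halogens read alike, and this single pair offers no explanation.

The compounds shown leave open whether this position accepts only halogens or also groups of another kind, such as a methoxy group, an amine, a carboxylic acid or a plain hydrogen, since the only exchange read here is between chloro and bromo. They also leave open whether the same exchange would read alike on the other chlorine-bearing ring, on the phenyl group carried by the shared core, or in the methoxyphenyl piperazine amides of compound 1 and compound 2.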